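A few compounds are considered here, and "the series" means these few. Any claim that something is new, unique, unknown or untested is made for them only; others in the source may bear on it.

Measured compounds:
compound 1, `O=C(COc1ccc(/C=C2\SC(=O)NC2=O)cc1)Nc1ccc([N+](=O)[O-])cc1`: 29500 nM
compound 2, `O=C(COc1ccc(/C=C2\SC(=O)NC2=O)cc1)Nc1cccc([N+](=O)[O-])c1`: 20500 nM

The account follows the step from compound 1 to compound 3, `Cc1ccc(NC(=O)COc2ccc(/C=C3\SC(=O)NC3=O)cc2)cc1Cl`, which has not yet been measured. In a functional assay on K562 cells (Homo sapiens) for inhibition (a higher number here means a weaker inhibitor of growth, a lower number a stronger inhibitor of growth), compound 1 gives 29500 nM, the highest of the two numbers shown, while compound 2 in this assay gives 20500 nM. Within the data shown here, the one measured step, a 1.4-fold lower number from compound 1 to compound 2 (0.16 log units; within the scatter), moves the nitro group around the ring and stays within the scatter, so it tells only that compound 1 and compound 2 behave alike.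

The change to compound 3 is different in kind: 3-chloro-4-methylphenyl in place of 4-nitrophenyl on an amide-type nitrogen. No measured step removes the nitro group or brings in a chlorine or a methyl group, so nothing shown bears directly on this change. Among the measured compounds shown here, with only the step from compound 1 to compound 2 as a guide, and that within the scatter, the expectation is that compound 3 stays near compound 1, with a wide range to cover the unknown effect of the new group. Compound 3 is therefore expected to give 20000 nM, between 6000 nM and 70000 nM, which means an expected step of a 1.5-fold lower number from compound 1 to compound 3 (0.17 log units; within the scatter).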

Compound 3, concentration for 50% growth inhibition: 19600 nM
Compound 3: middle estimate off by 1.0-fold (0.01 log units), on the high side; measured number inside the range.
By their numbers in this assay, from the lowest: compounds 3, 2 and 1 (each within the scatter of the next).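

In this assay, 3-chloro-4-methylphenyl on the amide-type nitrogen gives a 1.5-fold lower number from compound 1 to compound 3 (0.18 log units; within the scatter) and, measured against the other nitro compound, a 1.0-fold lower number from compound 2 to compound 3 (0.02 log units; within the scatter). Compounds 1 and 2 differed only in where the nitro group sat, whereas compound 3 has no nitro group at all: the group that enters has chlorine and a methyl group, and 0 hydrogen-bond acceptors where 4-nitrophenyl has 2, yet all three compounds lie within the scatter of one another, so among these compounds a nitro group is not required for a number of this size. No independent measurement is available to account for this closeness.

From the compounds shown here alone, all three compounds carry a substituted phenyl group on this nitrogen, so it remains open whether an amine, a carboxylic acid or a longer chain placed on that phenyl group, or a simple alkyl chain replacing it, would move the number beyond the scatter. The shared core is also the same throughout, so the compounds shown say nothing about what a change there would do in this assay.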